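The source may hold more compounds than are shown below. What is called first, only, known or untested is meant among the compounds shown, and "the series" means these compounds.

In a functional assay on MIA PaCa-2 cells (Homo sapiens) for cytotoxicity, read by MTT assay, with a stated time of 4 h (a lower number here means a stronger inhibitor, a higher number a weaker inhibitor), compound 1 (`COC1=CC(=O)c2c(COc3ccc(N)cc3)c(C)n(C)c2C1=O`) gives 504 nM and compound 2 (`COC1=CC(=O)c2c(COc3ccc(C(F)(F)F)cc3)c(C)n(C)c2C1=O`) gives 496 nM, so compound 2 stands level with compound 1. Among the measured compounds shown here, the only measured step, a 1.0-fold lower number from compound 1 to compound 2 (0.01 log units; within the scatter), puts trifluoromethyl in place of amino on an aromatic carbon. Compound 3 (`COC1=CC(=O)c2c(COc3ccc(F)cc3)c(C)n(C)c2C1=O`) changes that same group again, with fluoro in place of trifluoromethyl on an aromatic carbon. Since that single step stayed within the scatter, no step beyond the scatter is expected. The expected step is a 1.0-fold higher number from compound 2 to compound 3 (0.00 log units; within the scatter). The estimate for compound 3 is 500 nM, with an expected range of 240 nM to 1000 nM.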

Compound 3, half-maximal inhibitory concentration: 905 nM
Compound 3: middle estimate off by 1.8-fold (0.26 log units), on the low side; the range from low to high includes it.
By their numbers in this assay, from the lowest: compounds 2, 1 and 3 (each within the scatter of the next).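

On an aromatic carbon para to a large group, a third substituent now also stays within the scatter: fluoro in place of trifluoromethyl gives (a 1.8-fold higher number from compound 2 to compound 3 (0.26 log units; within the scatter)), and fluoro in place of amino gives (a 1.8-fold higher number from compound 1 to compound 3 (0.25 log units; within the scatter)). Amino, trifluoromethyl and fluoro therefore cannot be told apart at this position in this assay, although trifluoromethyl is the largest of these by heavy atoms. The compounds shown leave open whether a carboxylic acid, a nitrile or a longer chain such as butoxy here would move the number beyond the scatter. No measurement shown explains the result.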